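Trading 2-Chlorophenyl for Cyclopentyl on the Shared Core

The source may report more compounds than this note shows. Statements on the series, on what has been measured and on what is new or still open speak of the compounds shown alone.

Of the compounds shown here, two have been measured in an in vitro functional assay on cells for agonist activity at Bombesin receptor subtype-3 (Homo sapiens), read by luminescence and calcium flux; on this read-out higher numbers stand for an effect only at larger amounts of compound and lower numbers for an effect already at smaller amounts. Compound 1 `N#Cc1ccccc1Cc1cnc(CCc2ccc(-c3ccccc3C(=O)O)cc2)[nH]1` gives 5480 nM in this assay, and compound 2 `O=C(O)c1ccccc1-c1ccc(CCc2ncc(Cc3ccccc3Cl)[nH]2)cc1` gives 292 nM. Among the measured compounds shown here, the one measured step between them, a 19-fold lower number from compound 1 to compound 2 (1.27 log units; beyond the scatter), shows how much the group on this saturated chain carbon can move the number. For the measured compounds named here, compound 2 thus stands at the lowest of the two numbers, with compound 1 as its only neighbour, well beyond the scatter.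

Compound 3 `O=C(O)c1ccccc1-c1ccc(CCc2ncc(CC3CCCC3)[nH]2)cc1` differs from compound 2 by cyclopentyl in place of 2-chlorophenyl on a saturated chain carbon bound to an aromatic carbon. Going by the values given here, no measured step speaks to this change directly: the step from compound 1 to compound 2 swapped only one substituent on the six-membered aromatic ring, whereas here that whole ring leaves and a five-membered non-aromatic ring enters. The author expects a loss, a step of a 3.4-fold higher number from compound 2 to compound 3 (0.53 log units; beyond the scatter), with wide uncertainty because the step from compound 1 to compound 2 was a 19-fold lower number from compound 1 to compound 2 (1.27 log units; beyond the scatter) and marks this position as sensitive. Compound 3 is therefore estimated at 1000 nM, within a range from 250 nM to 4000 nM.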

Compound 3, half-maximal effective concentration: 133 nM
The estimate for compound 3 lay 7.5-fold (0.88 log units) above the measured number; measured number below the stated range.
By their numbers in this assay, from the lowest: compound 3; then compound 2; then compound 1.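

In this assay, among the compounds shown here, the earlier compounds varied only a substituent on the six-membered aromatic ring, whereas this change shows that the ring itself can be given up on the saturated chain carbon bound to an aromatic carbon: cyclopentyl in place of 2-chlorophenyl gives a 2.2-fold lower number from compound 2 to compound 3 (0.34 log units; beyond the scatter), a modest step in the favourable direction. Cyclopentyl in place of 2-cyanophenyl gives a 41-fold lower number from compound 1 to compound 3 (1.61 log units; beyond the scatter), the largest step among the three compounds, so an aromatic ring at this place is not required for the lowest number in the set. No further data are at hand to explain why the number falls with this change.

The compounds shown do not separate the removal of the chloro group from the replacement of the aromatic ring, a question that an unsubstituted phenyl at the same place would address. They also leave open whether cyclopentyl is special among groups without an aromatic ring, or whether cyclobutyl, cyclohexyl or an open isobutyl chain would give a similar number.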